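The source may hold more compounds than are shown below. What is called first, only, known or untested is meant among the compounds shown, and "the series" means these compounds.

Measured so far in a functional assay on CCRF-CEM cells (Homo sapiens) for cytotoxicity, read by MTT assay, with a stated time of 72 h; a lower number here means a stronger inhibitor of growth, a higher number a weaker inhibitor of growth:
- compound 1, `COc1ccc(CNc2nc([Se]C)nc3ccccc23)cc1`: > 100000 nM
- compound 2, `Nc1nc([SeH])nc2ncccc12`: 30900 nM
- compound 3, `[SeH]c1nc([SeH])c2cccnc2n1`: "not determined" (no result reported)

Among the compounds with values here, compound 2 holds the only number in this assay. For compound 1 the result is a limit of the assay, (the limit of > 100000 nM in this assay, at which 1 of the 3 values shown sits). Compound 3 has no result in this assay.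

Compound 4, `C[Se]c1nc(N)c2cccnc2n1`, differs from compound 2 by methyl in place of hydrogen on a selenium. Within the data shown here, no measured step between measured compounds bears on this change, so the expectation rests on compound 2 alone. The step from compound 2 to compound 4 is expected to be small, at most a modest loss of growth inhibition or nothing beyond the scatter, a 1.3-fold higher number from compound 2 to compound 4 (0.11 log units; within the scatter). Compound 4 is therefore estimated at 40000 nM, in the range 10000 nM to 150000 nM.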

Compound 4, concentration for 50% growth inhibition: 68400 nM
Compound 4: the middle estimate sits 1.7-fold (0.23 log units) below what was measured, within the range that was stated.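

Methyl in place of hydrogen on a selenium is the only change at this position that can be read in this assay: a 2.2-fold higher number from compound 2 to compound 4 (0.35 log units; beyond the scatter), a modest loss of growth inhibition. Compound 4 still gives a number and not a limit, so replacing the selenium hydrogen with methyl does not remove growth inhibition from the measurable range. Nothing at hand accounts for the size of this step.

Still open, from the compounds shown here alone, is whether a longer chain such as ethyl or a benzyl group on the selenium would continue this direction. Also open, going by these compounds, is how a hydroxyl or an amine in place of the selenium group would compare.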